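A few compounds are considered here, and "the series" means these few. Any claim that something is new, unique, unknown or untested is made for them only; others in the source may bear on it.

For the measured compounds named here, compound 3 `CCCCc1cnc(CCc2ccc(-c3ccccc3C(=O)O)cc2)[nH]1` is a carboxylic acid whose chain carries a propyl group, and in an in vitro functional assay on cells for agonist activity at Bombesin receptor subtype-3 (Homo sapiens), read by luminescence and calcium flux (on this read-out higher numbers stand for an effect only at larger amounts of compound and lower numbers for an effect already at smaller amounts), compound 3 gives 2710 nM, the second highest of the three numbers measured so far. Compound 1 `O=C(O)c1ccccc1-c1ccc(CCc2ncc(CC3CCOCC3)[nH]2)cc1` gives 338 nM and compound 2 `COc1cccc(Cc2cnc(CCc3ccc(-c4ccccc4C(=O)O)cc3)[nH]2)c1` gives 4120 nM. Replacing oxan-4-yl by propyl gave an 8.0-fold higher number from compound 1 to compound 3 (0.90 log units; beyond the scatter), while a 1.5-fold lower number from compound 2 to compound 3 (0.18 log units; within the scatter) stays within the scatter. Compound 4 `O=C(O)c1ccccc1-c1ccc(CCc2ncc(CCC3CCCCC3)[nH]2)cc1` differs from compound 3 by cyclohexyl in place of ethyl on a saturated chain carbon, two bonds along the chain from an aromatic carbon. Because compound 1, which carries a ring on the chain, gives 338 nM, adding a ring on the chain of compound 4 is expected to bring a modest step down, a 2.3-fold lower number from compound 3 to compound 4 (0.35 log units; beyond the scatter). Compound 4 is therefore estimated at 1200 nM, with a range from 400 nM to 3500 nM.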

Compound 4, half-maximal effective concentration: 642 nM
For compound 4 the middle estimate is 1.9-fold (0.27 log units) above the measured one, within the range that was stated.
By their numbers in this assay, from the lowest: compounds 1 and 4 (each within the scatter of the next); then compounds 3 and 2 (each within the scatter of the next).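

In this assay a second saturated ring on this chain repeats the low number of compound 1: cyclohexyl in place of ethyl (a 4.2-fold lower number from compound 3 to compound 4 (0.63 log units; beyond the scatter)) and cyclohexylmethyl in place of 3-methoxyphenyl (a 6.4-fold lower number from compound 2 to compound 4 (0.81 log units; beyond the scatter)) both lower the number. With cyclohexylmethyl in place of oxan-4-yl (a 1.9-fold higher number from compound 1 to compound 4 (0.28 log units; within the scatter)) the two saturated rings stay within the scatter, so the ring oxygen is not needed for a low number. Compound 2 goes against any rule for rings in general, since its aromatic ring stands with the open chain of compound 3.

As far as these compounds go, whether an amine on the cyclohexyl ring would keep this number stays open. No measured evidence explains these steps.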